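This account rests on a few compounds, and the source may have more. Where it says the series, first, only, none or still open, it means among the compounds named here.

Measured so far in a functional assay on MDA-MB-231 cells (Homo sapiens) for cytotoxicity, read by MTT assay, with a stated time of 24 h; a lower number here means a stronger inhibitor, a higher number a weaker inhibitor:
- compound 1 `Cc1ccc(/C=C2\CN(Cc3cn(Cc4ccc(F)cc4)nn3)C/C(=C\c3ccc(C)cc3)C2=O)cc1`: 26800 nM
- compound 2 `Cc1ccc(/C=C2\CN(Cc3cn(Cc4cccc(Cl)c4)nn3)C/C(=C\c3ccc(C)cc3)C2=O)cc1`: 9000 nM
- compound 3 `COc1ccc(/C=C2\CN(Cc3cn(Cc4ccc(F)cc4)nn3)C/C(=C\c3ccc(OC)cc3)C2=O)cc1`: 70700 nM

Compound 2 at 9000 nM has the lowest number of the three, which makes it the strongest inhibitor of this small set. Compound 4 `Cc1ccc(/C=C2\CN(Cc3cn(Cc4ccccc4Cl)nn3)C/C(=C\c3ccc(C)cc3)C2=O)cc1` has the same atoms as compound 2, joined differently: 2-chlorophenyl in place of 3-chlorophenyl on a saturated chain carbon bound to an aromatic nitrogen. In words, 2-chlorophenyl stands in place of 3-chlorophenyl on a saturated chain carbon bound to an aromatic nitrogen.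

Within the data shown here, only one measured step touches this place: a 3.0-fold lower number from compound 1 to compound 2 (0.47 log units; beyond the scatter). That modest step replaced 4-fluorophenyl with 3-chlorophenyl, so it does not isolate a move of the chlorine alone. Among the measured compounds shown here, no measured compound carries 2-chlorophenyl, which leaves the direction in this assay open. A step no larger than that one is the likeliest outcome. A slight rise is expected, because compound 2 at 9000 nM already has the lowest number of the three. The expected change is a 1.3-fold higher number from compound 2 to compound 4 (0.12 log units; within the scatter). For compound 4, the estimated value is 12000 nM, with an expected range of 4500 nM to 30000 nM.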

Compound 4, half-maximal inhibitory concentration: 29000 nM
Compound 4: middle estimate off by 2.4-fold (0.38 log units), on the low side; the range from low to high includes it.
By their numbers in this assay, from the lowest: compound 2; then compounds 1 and 4 (each within the scatter of the next); then compound 3.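

In this assay the chlorine changes place while every atom stays the same, and 2-chlorophenyl in place of 3-chlorophenyl gives a 3.2-fold higher number from compound 2 to compound 4 (0.51 log units; beyond the scatter) and so shows that the place of the chlorine on this ring matters, which the earlier step could not show because it changed both the halogen and its place at once. Replacing 4-fluorophenyl with 2-chlorophenyl gives a 1.1-fold higher number from compound 1 to compound 4 (0.03 log units; within the scatter) so this assay does not tell these two groups apart, and carrying a chlorine is therefore not enough on its own to give the lower number seen with 3-chlorophenyl. Nothing available explains why these changes in the group give these numbers.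

The compounds shown leave open how 4-chlorophenyl would compare with its 2-chlorophenyl and 3-chlorophenyl relatives, and whether a ring carrying an amine or a carboxylic acid in place of the halogen would keep any of this activity. They also leave open whether 3-chlorophenyl would give a similarly lower number on the methoxy-bearing core of compound 3.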